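This account rests on a few compounds, and the source may have more. Where it says the series, first, only, none or still open, it means among the compounds named here.

Compound 1 `Cc1ccc(N)cc1S(=O)(=O)N(C)/N=C/c1cnn2ccc(C#N)cc12`: "not determined" (no result reported)
Compound 2 `Cc1ccc(C)c(S(=O)(=O)N(C)/N=C/c2cnn3ccc(C#N)cc23)c1`: 2100 nM

Among the measured compounds shown here, in a functional assay on NZB5 cells (Homo sapiens) for inhibition, read by thymidine incorporation, with a stated time of 5 days (a lower number here means a stronger inhibitor, a higher number a weaker inhibitor), compound 2, at 2100 nM, holds the only number available, so it cannot yet be ranked against anything. Compound 3 `Cc1ccc(Br)cc1S(=O)(=O)N(C)/N=C/c1cnn2ccc(C#N)cc12` has bromo in place of methyl on an aromatic carbon, meta to a large group and para to a methyl group: bromo in place of methyl on an aromatic carbon. For the measured compounds named here, no measured step speaks to this change, so no step beyond the usual scatter is expected in this assay, and neither direction is firmly favoured. The expected change is a 1.3-fold lower number from compound 2 to compound 3 (0.12 log units; within the scatter). For compound 3 the estimated value is 1600 nM, with an expected range of 500 nM to 5000 nM.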

Compound 3, half-maximal inhibitory concentration: 700 nM
Beside the measured number, compound 3's estimate is 2.3-fold (0.36 log units) above it, within the range that was stated.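

In this assay bromo in place of methyl on this aromatic carbon, meta to a large group and para to a methyl group, gives a 3.0-fold lower number from compound 2 to compound 3 (0.48 log units; beyond the scatter) and so moves the number beyond the scatter. Among the compounds shown here, this shows that the read-out responds to the group at this position, though only a single pair supports that. Nothing shown explains why the number falls. On these data alone, what a methoxy group or a carboxylic acid would do at this position remains open. So does whether the same exchange would have a similar effect on another core.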